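This account rests on a few compounds, and the source may have more. Where it says the series, first, only, none or still open, it means among the compounds named here.

Measured compounds:
- compound 1, `Nc1ccc2c(c1)OCCCN2S(=O)(=O)c1ccc(-c2cnc(C3CC3)o2)cc1`: 87 nM
- compound 2, `O=S(=O)(c1ccc(-c2cnc(C3CC3)o2)cc1)N1CCOc2ccccc21`: 71 nM
- compound 3, `O=S(=O)(c1ccc(-c2cnc(C3CC3)o2)cc1)N1CCCCc2ccccc21`: 72 nM

All three compounds share the same sulfonyl-linked core and were tested in a functional assay on HCT-116 cells (Homo sapiens) for antiproliferative activity, read by MTT assay, with a stated time of 72 h; a higher number here means a weaker inhibitor, a lower number a stronger inhibitor. Compound 1 has the highest number of the three, yet its gaps to compound 2 and to compound 3 are both within the usual scatter, so the three cannot be placed in any order on these numbers alone. Compound 2 and compound 3 carry no group at all on the aromatic ring where compound 1 bears its amino group, and they give numbers close to that of compound 1.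

Compound 4, `Cc1ccc2c(c1)OCCCN2S(=O)(=O)c1ccc(-c2cnc(C3CC3)o2)cc1`, has not yet been measured. It differs from compound 1 in a single place: methyl in place of amino on an aromatic carbon. For the measured compounds named here, there is no measured pair showing what this exchange does, so the expectation rests on the fact that compound 2 and compound 3, lacking any group at that position, sit close to compound 1. On that basis the step of a 1.2-fold lower number from compound 1 to compound 4 (0.06 log units; within the scatter) is expected to stay within the scatter, with no clear direction. Compound 4 is therefore estimated at 75 nM, with a range from 35 nM to 170 nM.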

Compound 4, half-maximal inhibitory concentration: 766 nM
Estimate against measurement, compound 4: 10-fold (1.01 log units) below; the whole stated range lies below it.
By their numbers in this assay, from the lowest: compounds 2, 3 and 1 (each within the scatter of the next); then compound 4.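

Exchanging amino for methyl on this aromatic carbon gives, in this assay, an 8.8-fold higher number from compound 1 to compound 4 (0.94 log units; beyond the scatter). The position is therefore not indifferent to what sits on it: each group counts 1 heavy atom, so an exchange that leaves the heavy-atom count unchanged is enough to produce a step beyond the scatter, while the counts do differ in that amino has 1 hydrogen-bond donor and 1 hydrogen-bond acceptor and methyl has 0 of each. No measurement available here explains the size of this step.

On these data alone, whether a hydroxyl or a methoxy group on the same carbon would give a number close to that of compound 1 or that of compound 4 remains open. So does the number for a plain hydrogen at that carbon on the core of compound 1, and this single pair cannot show whether the step would recur on another core.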